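From Dichlorobenzyl to Fluorobenzyl on a Diamino Core

A few compounds are considered here, and "the series" means these few. Any claim that something is new, unique, unknown or untested is made for them only; others in the source may bear on it.

Measured compounds:
compound 1 `Nc1cc(N)c2nc(-c3ccccc3)c(NCc3ccc(Cl)c(Cl)c3)nc2c1` — 45700 nM
compound 2 `CCOC(=O)[C@H](CCC(=O)O)NC(=O)c1ccc(Oc2nc3cc(N)cc(N)c3nc2-c2ccccc2)cc1` — < 100000 nM (a limit of the assay)
compound 3 `CCOC(=O)[C@H](CCC(=O)O)NC(=O)c1ccc(CNc2nc3cc(N)cc(N)c3nc2-c2ccccc2)cc1` — < 100000 nM (a limit of the assay)

For the measured compounds named here, in a functional assay on NCI/ADR-RES cells (Homo sapiens) for inhibition, read by sulforhodamine B assay, with a stated time of 48 h (a lower number here means a stronger inhibitor of growth, a higher number a weaker inhibitor of growth), compound 1 gives 45700 nM, the only actual number among the three measured compounds. Compound 2 gives < 100000 nM, which is a limit of the assay rather than a number. Compound 3 likewise gives < 100000 nM, also a limit. Compound 1 therefore stands alone as the single fixed point; the other two values sit at the limit of < 100000 nM in this assay, at which 2 of the 3 values shown sit, and cannot be placed relative to it.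

Compound 4 `Nc1cc(N)c2nc(-c3ccccc3)c(NCc3ccc(F)cc3)nc2c1` has not yet been measured. It differs from compound 1 by 4-fluorophenyl in place of 3,4-dichlorophenyl on a saturated chain carbon bound to a nitrogen on an aromatic ring. No measured pair shows a change of this kind, so the direction and size of the step rest on no shown evidence. A step of a 1.3-fold higher number from compound 1 to compound 4 (0.12 log units; within the scatter) is expected, leaning toward weaker growth inhibition but of a size near the usual scatter. Compound 4 is thus estimated at 60000 nM, within a range from 20000 nM to 150000 nM.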

Compound 4, concentration for total growth inhibition: 5750 nM
Beside the measured number, compound 4's estimate is 10-fold (1.02 log units) above it; measured number below the stated range.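

In this assay, for the compounds shown here, this is the first readable step at this position, on a saturated chain carbon bound to a nitrogen on an aromatic ring: going from 3,4-dichlorobenzyl to 4-fluorobenzyl gives a 7.9-fold lower number from compound 1 to compound 4 (0.90 log units; beyond the scatter). With a single number on the shared core, nothing could yet show that growth inhibition responds to a change in this benzyl group, and now it clearly does. No measurement shown gives a reason for this step.

The change alters the halogens in more than one way, so this pair cannot say which part of it matters; a 4-chlorobenzyl or a plain benzyl group would begin to separate those parts. Steps involving compounds 2 and 3 cannot be read, as each of their values is a limit of the assay and not a number.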